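Shortening the Amine Toward an Ethylamino Variant

The compounds below may be only part of what the source reports. "The series", "measured", "known", "first", "only" and "open" are said of these compounds alone.

Compound 2 `COc1ccccc1-c1cc(C2CCN(C)C2)ccc1Cl` gives the highest of the two plain numbers in an assay on isolated protein for binding affinity to 5-hydroxytryptamine receptor 5A (Homo sapiens) (on this read-out lower numbers stand for stronger inhibition and higher numbers for weaker inhibition), with 1000 nM. Compound 3 `CNCc1ccc(Cl)c(-c2ccccc2OC)c1` gives 420 nM in this assay. Compound 1 `CCCN(CCC)Cc1ccc(Cl)c(-c2ccccc2OC)c1` reaches only the limit > 10000 nM in this assay, a limit rather than a number. The step of a 2.4-fold lower number from compound 2 to compound 3 (0.38 log units; beyond the scatter) was modest, while the step of an at least 23-fold lower number from compound 1 to compound 3 (1.37 log units; beyond the scatter) was large. Compound 4 `CCNCc1ccc(Cl)c(-c2ccccc2OC)c1` differs from compound 2 by (ethylamino)methyl in place of 1-methylpyrrolidin-3-yl on an aromatic carbon. Both measured steps bear on this change: the open-chain methylamino compound gave a lower number than the ring, and a much lower number than the dipropylamino compound. Ethylamino is a small move from methylamino toward dipropylamino, so the step of a 1.7-fold lower number from compound 2 to compound 4 (0.22 log units; within the scatter) is expected to be a small lowering, near the scatter. Compound 4 is therefore estimated at 600 nM, within 250 nM to 1500 nM.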

Compound 4, inhibition constant: 1800 nM
For compound 4 the middle estimate is 3.0-fold (0.48 log units) below the measured one; measured number outside the range, above it.
By their numbers in this assay, from the lowest: compound 3; then compounds 2 and 4 (each within the scatter of the next). At a limit, above all of these: compound 1.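

Going from methylamino to ethylamino is enough to give a 4.3-fold higher number from compound 3 to compound 4 (0.63 log units; beyond the scatter), so the gain seen for the open chain belongs to methylamino and does not extend to the next larger amine. With ethylamino, the open chain no longer stands apart from the ring: a 1.8-fold higher number from compound 2 to compound 4 (0.26 log units; within the scatter). Toward dipropylamino there is an at least 5.5-fold lower number from compound 1 to compound 4 (0.74 log units; beyond the scatter), a step that rests on a limit rather than a number: the limit of > 10000 nM in this assay, at which 1 of the 4 values shown sits.

Still open, as far as these compounds go, is how an unsubstituted aminomethyl group or a dimethylamino group would compare with methylamino at this position. A single propylamino group could also show how the numbers run between ethylamino and dipropylamino.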